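This account rests on a few compounds, and the source may have more. Where it says the series, first, only, none or still open, it means among the compounds named here.

Measured in a functional assay on the whole organism (CCRF S-180 cells, Mus musculus) for inhibition, in a xenograft, with stated times of 7 days and 24 h, at a dose of 100 umol/kg by the intraperitoneal route; a lower number here means less inhibition, a higher number more inhibition at the dose given (going by the name of the read-out):

compound 1, `NC(=O)C[C@H](NC(=O)c1cc2ccccc2cn1)C(=O)OCc1ccccc1`: 36.7%
compound 2, `O=C(C[C@@H]1CCCN1C(=O)c1cc2ccccc2cn1)OCc1ccccc1`: 44.5%

Compound 1 gives the lower of the two numbers in this assay, but the gap to compound 2 lies within the scatter, so no order between the two can be read from them.

Compound 3, `O=C(N[C@@H](CO)C(=O)OCc1ccccc1)c1cc2ccccc2cn1`, is not yet measured. It differs from compound 1 in one place: hydroxy in place of carbamoyl on a saturated chain carbon, two bonds along the chain from an amide-type nitrogen and a carbonyl carbon. Among the compounds with values here, no step between two measured compounds is available that would show what such a change does in this assay, and the two measured numbers themselves lie within the scatter of each other. The step from compound 1 to compound 3 is therefore expected to be small, a number 1.3 percentage points higher from compound 1 to compound 3 (within the scatter), with no direction that stands beyond the scatter.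

For compound 3 the estimated inhibition is 38%, expected to fall between 22% and 54%.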

Compound 3, a percentage reported as inhibition, in the whole organism at one dose (the size of the read-out at that dose, not a potency): 40.4%
The estimate for compound 3 lay 2.4 percentage points below the measured number; the measured number falls inside the stated range.
By their numbers in this assay, from the lowest: compounds 1, 3 and 2 (each within the scatter of the next).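

In this assay, hydroxy in place of carbamoyl on a saturated chain carbon, two bonds along the chain from an amide-type nitrogen and a carbonyl carbon, gives a number 3.7 percentage points higher from compound 1 to compound 3 (within the scatter), the only single-place comparison shown so far. At this place, carbamoylmethyl and hydroxymethyl therefore cannot be told apart in this assay, so the carbamoyl group is not required for an inhibition of this size at the dose given. No supporting measurement is available to explain this result.

From the compounds shown here alone, whether an amine, a carboxylic acid or a longer chain at the same place would give a step beyond the scatter remains open. A plain methyl group there would also show whether either hydrogen-bonding group contributes at all in this assay.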